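Phenyl for cyclohexylmethyl on the shared core

The source may hold more compounds than are shown below. What is called first, only, known or untested is meant among the compounds shown, and "the series" means these compounds.

In a functional assay on HOS cells (Homo sapiens) for antiproliferative activity, read by sulforhodamine B assay (on this read-out higher numbers stand for weaker inhibition of growth and lower numbers for stronger inhibition of growth), compound 1 `O[C@H]1CO[C@H](COCc2ccccc2)[C@@H](OCc2ccccc2)[C@@H]1OCc1ccccc1` gives 37900 nM and compound 2 `CCC[C@@H]1O[C@H](COCc2ccccc2)[C@@H](OCc2ccccc2)[C@H](OCc2ccccc2)[C@H]1O` gives 38600 nM with no real separation (a 1.0-fold higher number from compound 1 to compound 2 (0.01 log units; within the scatter)). Compound 3 `O[C@@H]1[C@@H](OCc2ccccc2)[C@H](OCc2ccccc2)[C@@H](COCc2ccccc2)O[C@H]1CC1CCCCC1` gives 4400 nM as the lowest number of the three, set apart from both (an 8.6-fold lower number from compound 1 to compound 3 (0.94 log units; beyond the scatter) and an 8.8-fold lower number from compound 2 to compound 3 (0.94 log units; beyond the scatter)). Compound 4 `O[C@@H]1[C@@H](OCc2ccccc2)[C@H](OCc2ccccc2)[C@@H](COCc2ccccc2)O[C@H]1c1ccccc1` has phenyl in place of cyclohexylmethyl on a saturated ring carbon. Going by the values given here, no measured compound carries phenyl at this place, and propyl in compound 2 brought no change. Part of the drop seen for compound 3 (an 8.8-fold lower number from compound 2 to compound 3 (0.94 log units; beyond the scatter)) is therefore expected to be lost, giving a smaller move back toward a higher number. In this assay the estimated step is a 3.4-fold higher number from compound 3 to compound 4 (0.53 log units; beyond the scatter) and remains uncertain. The expected value for compound 4 is 15000 nM within an estimated range of 4500 nM to 45000 nM for now.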

Compound 4, concentration for 50% growth inhibition: > 50000 nM
Compound 4 was reported as a limit; the forecaster's own chance of this, stated with the estimate: 3%; at least 3.3-fold (0.52 log units) between middle value and limit.
By their numbers in this assay, from the lowest: compound 3; then compounds 1 and 2 (each within the scatter of the next). At a limit, above all of these: compound 4.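

Phenyl in place of cyclohexylmethyl at this saturated ring carbon next to the ring oxygen gives a large step toward weaker inhibition of growth: an at least 11-fold higher number from compound 3 to compound 4 (1.05 log units; beyond the scatter). Compound 4 is reported only as a limit in this assay: the limit of > 50000 nM in this assay, at which 1 of the 4 values shown sits. The other two steps cannot be read, as their floors lie within the scatter: an at least 1.2-fold higher number from compound 2 to compound 4 (0.11 log units; that floor lies within the scatter) and an at least 1.3-fold higher number from compound 1 to compound 4 (0.12 log units; that floor lies within the scatter).

Still open, going by these compounds, is whether benzyl or cyclohexyl at this ring carbon would give a number nearer that of compound 3 or compound 4. On these data alone, the effect of an amine at this place also remains open.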